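Shortening the ether chain on a chalcone core

A few compounds are considered here, and "the series" means these few. Any claim that something is new, unique, unknown or untested is made for them only; others in the source may bear on it.

Three measured compounds share one core and differ only in the alkyl group attached through an oxygen to the aromatic ring. Compound 1 `CC(C)(C)CCOc1cccc(O)c1C(=O)/C=C/c1ccc(O)cc1` gives 3300 nM in a functional assay on NUGC-3 cells (Homo sapiens) for antiproliferative activity, read by sulforhodamine B assay; a higher number here means a weaker inhibitor of growth, a lower number a stronger inhibitor of growth. Compound 2 `CC(C)COc1cccc(O)c1C(=O)/C=C/c1ccc(O)cc1` gives 2980 nM in this assay, and compound 3 `CCC(CC)COc1cccc(O)c1C(=O)/C=C/c1ccc(O)cc1` gives 1960 nM. Compound 3 has the lowest number of the three, but its gap to the others is within the scatter: a 1.5-fold lower number from compound 2 to compound 3 (0.18 log units; within the scatter) and a 1.7-fold lower number from compound 1 to compound 3 (0.23 log units; within the scatter). The step from compound 1 to compound 2 is also within the scatter: a 1.1-fold lower number from compound 1 to compound 2 (0.04 log units; within the scatter).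

Compound 4 `CCCCOc1cccc(O)c1C(=O)/C=C/c1ccc(O)cc1` comes from compound 3 by the change (hydrogen in place of ethyl on a saturated chain carbon bound to two saturated chain carbons). All three measured steps reshape the same alkyl ether, and none moved the number beyond the scatter, so the step to compound 4 in this assay is expected to be similarly small, at most a slight rise. The expected step is a 1.3-fold higher number from compound 3 to compound 4 (0.11 log units; within the scatter). Compound 4 is therefore estimated at 2500 nM, with a range from 1200 nM to 5200 nM.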

Compound 4, concentration for 50% growth inhibition: > 30000 nM
Compound 4: a limit, no number; the forecaster's own chance of this, stated with the estimate: 2%; middle value at least 12-fold (1.07 log units) from the limit.
By their numbers in this assay, from the lowest: compounds 3, 2 and 1 (each within the scatter of the next). At a limit, above all of these: compound 4.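

Until now, reshaping the ether group hardly seemed to matter, since the three branched groups stayed within the scatter of one another, yet this position proves sensitive to the swap of 2-ethylbutoxy for straight butoxy. In this assay, compound 4 stands at a limit and not at a number: the limit of > 30000 nM in this assay, at which 1 of the 4 values shown sits. Taking hydrogen in place of ethyl gives an at least 15-fold higher number from compound 3 to compound 4 (1.18 log units; beyond the scatter), and the other two comparisons agree, with an at least 10-fold higher number from compound 2 to compound 4 (1.00 log units; beyond the scatter) and an at least 9.0-fold higher number from compound 1 to compound 4 (0.95 log units; beyond the scatter), so among these four compounds only the unbranched chain falls out of the measurable range.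

From the compounds shown here alone, whether any straight chain behaves this way remains open, and a longer chain such as hexyl would test that. So does whether a butyl chain ending in an amine or a carboxylic acid would behave like butoxy.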